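Ester to Carbamate: Estimating Compound 4 Before Measurement

This account rests on a few compounds, and the source may have more. Where it says the series, first, only, none or still open, it means among the compounds named here.

In an assay on frontal cortex for displacement of a labelled ligand from corticotropin-releasing factor receptor 1 (Rattus norvegicus), with a stated time of 2 h (a lower number here means a stronger inhibitor, a higher number a weaker inhibitor), three compounds have so far been measured:
compound 1, `COc1nc(C)c(Nc2nc(Cl)cn([C@H](CO)C3CC3)c2=O)cc1C`, gives 88 nM;
compound 2, `COc1nc(C)c(Nc2nc(Cl)cn([C@H](COC(=O)c3cccnc3)C3CC3)c2=O)cc1C`, gives 5.2 nM;
compound 3, `COc1nc(C)c(Nc2nc(Cl)cn([C@H](COC(=O)Nc3cc(Cl)cc(Cl)c3)C3CC3)c2=O)cc1C`, gives 1.7 nM.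

Compound 2 stands second highest of these three numbers. Its nearest neighbour is compound 3, with a 3.1-fold lower number from compound 2 to compound 3 (0.49 log units; beyond the scatter), and its furthest is compound 1, with a 17-fold lower number from compound 1 to compound 2 (1.23 log units; beyond the scatter). Both acylations of the free hydroxyl gave large steps, the larger being a 52-fold lower number from compound 1 to compound 3 (1.71 log units; beyond the scatter).

Compound 4, `COc1nc(C)c(Nc2nc(Cl)cn([C@H](COC(=O)Nc3cccc(C#N)c3)C3CC3)c2=O)cc1C`, has not yet been measured. It differs from compound 2 in one place: (3-cyanophenyl)amino in place of pyridin-3-yl on a carbonyl carbon. For the measured compounds named here, the step that bears on this is the one from compound 2 to compound 3, where a (3,5-dichlorophenyl)amino group replaced the same pyridin-3-yl and the number fell by a 3.1-fold lower number from compound 2 to compound 3 (0.49 log units; beyond the scatter). Compound 4 carries a (3-cyanophenyl)amino group in that position, so a modest lowering is expected, estimated as a 2.1-fold lower number from compound 2 to compound 4 (0.32 log units; beyond the scatter). Compound 4 is therefore expected at 2.5 nM, with a range from 1 nM to 7 nM.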

Compound 4, half-maximal inhibitory concentration: 1.3 nM
Compound 4: the middle estimate sits 1.9-fold (0.28 log units) above what was measured, within the range that was stated.
By their numbers in this assay, from the lowest: compounds 4 and 3 (each within the scatter of the next); then compound 2; then compound 1.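

In this assay, the gain over the pyridin-3-yl ester recurs with a second aryl carbamate, at a 4.0-fold lower number from compound 2 to compound 4 (0.60 log units; beyond the scatter), so it is not confined to the 3,5-dichlorophenyl group. Exchanging the aryl group on the amide-type nitrogen gives a 1.3-fold lower number from compound 3 to compound 4 (0.12 log units; within the scatter), so in this position 3-cyanophenyl and 3,5-dichlorophenyl cannot be told apart, while acylating the free hydroxyl again gives a large step, a 68-fold lower number from compound 1 to compound 4 (1.83 log units; beyond the scatter). Nothing measured here accounts for these steps.

Still open, going by these compounds, is how much of the gain belongs to the amide-type nitrogen and how much to the aryl ring, which a pyridin-3-yl carbamate or a 3-cyanophenyl ester would help to separate. Also open, on these data alone, is how a methyl or cyclohexyl group on that nitrogen would compare with the aryl groups.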